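Swapping the group on the amide carbonyl of compound 1

A few compounds are considered here, and "the series" means these few. Any claim that something is new, unique, unknown or untested is made for them only; others in the source may bear on it.

In an ADME assay on microsomes from liver (Homo sapiens) for metabolic stability, read by LC-MS, with a stated time of 30 min, tested at 1 uM (on this read-out lower numbers stand for a less stable compound and higher numbers for a more stable compound), compound 1 (`O=C(NCc1ccc(S(=O)(=O)c2ccccc2)cc1)c1nc2ccncc2s1`) gives 68% and serves as the reference point. Compound 3 (`Cn1c(C(=O)NCc2ccc(S(=O)(=O)c3ccccc3)cc2)cc2ccncc21`) gives 71% and lies within the scatter of compound 1. Compound 2 (`O=C(NCc1ccc(S(=O)(=O)c2ccccc2C(F)(F)F)cc1)c1cc2cnccc2[nH]1`) gives 52% and falls beyond the scatter below compound 1. Compound 1 therefore stands with compound 3 in the upper part of this small set.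

Compound 4 (`O=C(NCc1ccc(S(=O)(=O)c2ccccc2)cc1)c1c[nH]c2ccncc12`) is still unmeasured and differs from compound 1 by a group of 9 heavy atoms (7 carbon, 2 nitrogen; one five-membered aromatic ring with 1 hetero atom, one six-membered aromatic ring with 1 hetero atom) in place of a group of 9 heavy atoms (6 carbon, 2 nitrogen, 1 sulfur; one five-membered aromatic ring with 2 hetero atoms, one six-membered aromatic ring with 1 hetero atom), on a carbonyl carbon and nothing else. For the measured compounds named here, no two measured compounds differ in one place only, so no measured step speaks directly to this change. Compound 3 also carries a five-membered aromatic ring with 1 hetero atom on the carbonyl carbon and gives 71% as indirect support for a number near that of compound 1. Compound 2 has such a ring too and gives 52% but also carries a trifluoromethyl group, so it says little about this change alone. In this assay the expected outcome is a number 5 percentage points lower from compound 1 to compound 4 (within the scatter) as a slight fall that is not expected to exceed the scatter. For compound 4 the estimated value is 63% with an expected range from 46% to 79% as the working figure.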

Compound 4, percent of the compound remaining: > 99%
Compound 4 was reported as a limit; the forecaster's own chance of this, stated with the estimate: 2%; middle value at least 36 percentage points away from the limit.
By their numbers in this assay, from the lowest: compound 2; then compounds 1 and 3 (each within the scatter of the next). At a limit, above all of these: compound 4.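

For the compounds shown here, the swap on the carbonyl carbon gives the first step that changes one place only, and in this assay that step is large: a number at least 31 percentage points higher from compound 1 to compound 4 (beyond the scatter). The group on the carbonyl carbon can therefore move this read-out well beyond the scatter, even though the number of heavy atoms stays the same and the shared remainder of compound 1 is untouched. For compound 4, > 99% is a limit and not a number: the limit of > 99% in this assay, at which 1 of the 4 values shown sits.

The step speaks only for this pair, since compound 2 and compound 3 also carry a five-membered aromatic ring with 1 hetero atom but differ from compound 4 in more than one place, and the swap removes sulfur while also changing the counts of hydrogen-bond donors and acceptors, with no compound shown separating these changes. Also open, on these data alone, is how the group that enters would respond to a fluorine atom, a nitrile or an amine added to it, and whether it would give the same result with a trifluoromethyl group elsewhere in the compound.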